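The compounds below may be only part of what the source reports. "The series", "measured", "known", "first", "only" and "open" are said of these compounds alone.

Compound 1 `CC(C(=O)O)c1nn(Cc2cn3cc(OCC4CC4)c(Cl)cc3n2)c2ccccc2c1=O` gives 31 nM in a functional assay on CHO cells for antagonist activity at sphingosine 1-phosphate receptor 2 (Homo sapiens), read by GTPgammaS binding; on this read-out higher numbers stand for weaker inhibition and lower numbers for stronger inhibition. Compound 2 `C[C@@H](C(=O)O)c1nn(Cc2cn3cc(OCC4CC4)c(Cl)cc3n2)c2ccccc2c1=O` gives 253 nM in this assay, and compound 3 `CCC(C(=O)O)c1nn(Cc2cn3cc(OCC4CC4)c(Cl)cc3n2)c2ccccc2c1=O` gives 43 nM. Among the three numbers compound 3 is second highest, though a 1.4-fold higher number from compound 1 to compound 3 (0.14 log units; within the scatter) lies within the scatter, whereas a 5.9-fold lower number from compound 2 to compound 3 (0.77 log units; beyond the scatter) goes beyond it. For the measured compounds named here, the step of an 8.2-fold higher number from compound 1 to compound 2 (0.91 log units; beyond the scatter) also goes beyond the scatter; the sole difference in that pair is the fact that one of compounds 1 and 2 is drawn with a defined configuration and the other without, at the place where they differ. Compound 4 `C[C@H](C(=O)O)c1nn(Cc2cn3cc(OCC4CC4)c(Cl)cc3n2)c2ccccc2c1=O` differs from compound 3 by 1-carboxyethyl in place of 1-carboxypropyl on an aromatic carbon. The steps bearing on it are a 5.9-fold lower number from compound 2 to compound 3 (0.77 log units; beyond the scatter) and a 1.4-fold higher number from compound 1 to compound 3 (0.14 log units; within the scatter); compound 4 carries the configuration opposite to compound 2, while compound 1 is drawn without one. A step down, beyond the scatter, is expected: a 2.7-fold lower number from compound 3 to compound 4 (0.43 log units; beyond the scatter). Compound 4 is expected at 16 nM, between 6 nM and 45 nM.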

Compound 4, half-maximal inhibitory concentration: 16 nM
Estimate against measurement, compound 4: no gap at the digits printed; the range from low to high includes it.
By their numbers in this assay, from the lowest: compounds 4, 1 and 3 (each within the scatter of the next, the first and the last beyond it); then compound 2.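

In this assay, for the compounds shown here, the configuration at the saturated chain carbon of 1-carboxyethyl matters, with a 16-fold lower number from compound 2 to compound 4 (1.20 log units; beyond the scatter), and the sole difference in that pair is this: the fact that compounds 2 and 4 differ only in the configuration as drawn. The form without a drawn configuration does not separate from the S form, with a 1.9-fold lower number from compound 1 to compound 4 (0.29 log units; within the scatter), and the only difference there is this: the fact that one of compounds 1 and 4 is drawn with a defined configuration and the other without, at the place where they differ. Against 1-carboxypropyl, the S form of 1-carboxyethyl gives a 2.7-fold lower number from compound 3 to compound 4 (0.43 log units; beyond the scatter), but that step changes the chain and the drawn configuration together.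

On these data alone, compound 3 is drawn without a configuration, so the effect of a defined one on 1-carboxypropyl stays open. Also open, as far as these compounds go, is the outcome of a longer chain, such as 1-carboxybutyl, or of an amide in place of the carboxylic acid.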